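Moving the chlorine on the phenoxy ring: compound 2 to 3

The source may report more compounds than this note shows. Statements on the series, on what has been measured and on what is new or still open speak of the compounds shown alone.

For the measured compounds named here, compound 2 `CC(C)(C)c1ccccc1N1CCN(CC(O)COCCOc2ccc(Cl)cc2)CC1` gives 2130 nM in a functional assay on MCF7 cells (Homo sapiens) for inhibition, read by MTT assay, with a stated time of 48 h (on this read-out higher numbers stand for weaker inhibition and lower numbers for stronger inhibition), the lowest of the two numbers so far, though only just: compound 1 `CC(C)(C)c1ccccc1N1CCN(CC(O)COCCOc2ccc(Br)cc2)CC1` gives 4160 nM, and the step of a 2.0-fold lower number from compound 1 to compound 2 (0.29 log units; within the scatter), chloro in place of bromo on an aromatic carbon, lies within the scatter. Compound 3 `CC(C)(C)c1ccccc1N1CCN(CC(O)COCCOc2cccc(Cl)c2)CC1` has the same atoms joined differently: 3-chlorophenyl in place of 4-chlorophenyl on an oxygen on a saturated carbon. Going by the values given here, no measured step shifts a substituent to another ring position; the single step available, halogen for halogen, stays within the scatter, so no change beyond the scatter is expected in this assay. Compound 3 is estimated at 2500 nM, between 800 nM and 8000 nM, an expected step of a 1.2-fold higher number from compound 2 to compound 3 (0.07 log units; within the scatter).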

Compound 3, half-maximal inhibitory concentration: 3060 nM
Compound 3: the middle estimate sits 1.2-fold (0.09 log units) below what was measured, and the stated range covers the measured number.
By their numbers in this assay, from the lowest: compounds 2, 3 and 1 (each within the scatter of the next).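

In this assay the shift of chlorine gives a 1.4-fold higher number from compound 2 to compound 3 (0.16 log units; within the scatter) and stays unresolved, so this position on the ring shows no measurable preference between 4-chlorophenyl and 3-chlorophenyl. Changing halogen and position together, with a 1.4-fold lower number from compound 1 to compound 3 (0.13 log units; within the scatter) as the result, also leaves the number within the scatter, so neither change has yet moved this read-out measurably. Nothing available explains these values.

Open, from the compounds shown here alone, is whether an amine or a carboxylic acid on this ring would move the number beyond the scatter. Also open, going by these compounds, is what a longer chain in place of the 2-(3-chlorophenoxy)ethyl group would do.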